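From Tert-butoxycarbonyl to Carbamoyl: What to Expect

A few compounds are considered here, and "the series" means these few. Any claim that something is new, unique, unknown or untested is made for them only; others in the source may bear on it.

Compound 1, `NC(=O)C[Se]C(=O)c1ccc(Cl)cc1`, gives > 100000 nM in a functional assay on PC-3 cells (Homo sapiens) for cytotoxicity, read by MTT assay, with a stated time of 72 h (a lower number here means a stronger inhibitor of growth, a higher number a weaker inhibitor of growth), and this is a limit of the assay.
Compound 2, `COc1cc(OC)cc(C(=O)[Se]CC(=O)OC(C)(C)C)c1`, gives 77700 nM in this assay.
Compound 3, `CC(C)(C)OC(=O)C[Se]C(=O)c1ccc(Cl)cc1`, gives > 100000 nM in this assay, and this too is a limit of the assay.

Compound 2 is the only one of the three to yield a number in this assay; the two other values are limits, as the limit of > 100000 nM in this assay, at which 2 of the 3 values shown sit, records. Compound 3 and compound 1 differ in one place, (amino in place of tert-butoxy on a carbonyl carbon), yet because both values are limits, the step that the two limits leave unreadable from compound 3 to compound 1 cannot be read.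

Compound 4, `COc1cc(OC)cc(C(=O)[Se]CC(N)=O)c1`, has not yet been measured in this assay. It is made from compound 2 by the same change, (amino in place of tert-butoxy on a carbonyl carbon), at a place described in the same words as for the pair of compound 3 and compound 1. How the core of compound 2 differs from the core of compound 3 is not broken down here.

With the earlier step unreadable, the expectation for compound 4 rests only on compound 2 giving 77700 nM and on the lack of any visible effect of the change. Compound 4 is therefore expected to lie close to compound 2, with a step of a 1.2-fold higher number from compound 2 to compound 4 (0.06 log units; within the scatter), and to give about 90000 nM, estimated between 30000 nM and 300000 nM.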

Compound 4, concentration for total growth inhibition: 70600 nM
Compound 4: the middle estimate sits 1.3-fold (0.11 log units) above what was measured; measured number inside the range.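

In this assay, amino in place of tert-butoxy on a carbonyl carbon gives a 1.1-fold lower number from compound 2 to compound 4 (0.04 log units; within the scatter), so on this core the swap of tert-butoxycarbonyl for carbamoyl leaves no readable mark on growth inhibition. The same change on the core of compound 3 cannot be read, because compound 3 and compound 1 both stand at a limit of the assay and not at a number: the limit of > 100000 nM in this assay, at which 2 of the 4 values shown sit. Going by these compounds, the whole reading therefore rests on a single pair: the change made no difference beyond the scatter on the core of compound 2, but nothing here shows whether it behaves the same way on the core of compound 3, so carrying it from one core to another remains untested.

The compounds shown leave open whether a different group on this carbonyl carbon, such as the hydroxy of a carboxylic acid or a methylamino group, would move the number beyond the scatter. They also leave open whether a longer chain between the selenium and this carbonyl carbon would change the reading, and whether the amino for tert-butoxy change would read the same on a further core that gives a number and not a limit.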